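Methoxy added to the anilino ring of a chloropyrimidine

A few compounds are considered here, and "the series" means these few. Any claim that something is new, unique, unknown or untested is made for them only; others in the source may bear on it.

Three compounds share a chloropyrimidine core carrying two amino substituents. Compound 1 `Cc1ccccc1Nc1nc(NC2CCCCC2)ncc1Cl` bears a cyclohexylamino group and a 2-methylanilino group. In a functional assay on Jurkat cells (Homo sapiens) for inhibition, read by CCK-8 assay, with a stated time of 48 h (a lower number here means a stronger inhibitor of growth, a higher number a weaker inhibitor of growth), compound 1 gives only a limit, > 100000 nM, not a number. Compound 2 `CN1CCN(c2ccc(Nc3ncc(Cl)c(Nc4ccccc4)n3)nc2)CC1` carries a methylpiperazinyl-pyridinylamino group together with a plain anilino group. In this assay compound 2 likewise reaches only a limit, > 100000 nM, and no number. So compound 2 stands at the same limit as compound 1, and the limit of > 100000 nM in this assay, at which 2 of the 2 values shown sit, shows that every value in this set is such a limit.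

Compound 3 `COc1cccc(Nc2nc(Nc3ccc(N4CCN(C)CC4)cn3)ncc2Cl)c1` differs from compound 2 in one place: methoxy in place of hydrogen on an aromatic carbon. Cut one bond further out, the change reads anilino to (3-methoxyphenyl)amino. Among the compounds with values here, no measured step between two compounds in this set is available, so the size of the step is open. Since compound 2 sits at the limit > 100000 nM, the expectation is that compound 3 remains near that limit, with a step of a number no higher from compound 2 to compound 3 (the limit leaves the size open) of no clear direction beyond the scatter. Compound 3 is therefore estimated at 100000 nM, within a range from 30000 nM to 300000 nM.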

Compound 3, concentration for 50% growth inhibition: 15800 nM
Beside the measured number, compound 3's estimate is 6.3-fold (0.80 log units) above it; the measured number lies below the stated range.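

In this assay, the phenyl ring of the anilino group proves responsive to substitution: methoxy in place of hydrogen, which turns anilino into (3-methoxyphenyl)amino, gives an at least 6.3-fold lower number from compound 2 to compound 3 (0.80 log units; beyond the scatter). Within the data shown here, compound 3 is the only compound here with a number rather than a limit, so this single change is enough to bring growth inhibition into the measurable range, something compound 1 and compound 2 could not show. The true size of the step remains unknown, and only its lower bound can be read, since the starting point is a limit and not a number: the limit of > 100000 nM in this assay, at which 2 of the 3 values shown sit.

The compounds shown leave open whether the methoxy group itself matters or whether another group at the same place, such as hydroxy, ethoxy or a chlorine atom, would give a similar or larger step. They also leave open whether methoxy would do the same on another aromatic carbon of that ring, or on the 2-methylanilino group of compound 1.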